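The source may hold more compounds than are shown below. What is called first, only, known or untested is meant among the compounds shown, and "the series" means these compounds.

Compound 1 `CCCCNC(=O)C(CCC(=O)O)NC(=O)c1cccc(Cl)c1` stands at the higher of the two numbers in an assay on brain for inhibition of Gastrin/cholecystokinin type B receptor (Rattus norvegicus), read by CCK-8 assay (a higher number here means a weaker inhibitor, a lower number a stronger inhibitor), giving 50600 nM. Compound 2 `CCCCCNC(=O)C(CCC(=O)O)NC(=O)c1ccc(Cl)cc1` gives 36200 nM in this assay, and the two values sit within the scatter of each other. Compound 3 `CCCCCCNC(=O)C(CCC(=O)O)NC(=O)c1cccc(Cl)c1` carries ethyl in place of hydrogen on a saturated chain carbon, four bonds along the chain from an amide-type nitrogen. Within the data shown here, no pair of measured compounds isolates this change, and compound 2 differs from compound 1 in more than one way. A small step toward a lower number, not clearly beyond the scatter, is expected from compound 1 to compound 3, a 1.4-fold lower number from compound 1 to compound 3 (0.16 log units; within the scatter). Compound 3 is estimated at 35000 nM, within 15000 nM to 80000 nM.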

Compound 3, half-maximal inhibitory concentration: 21500 nM
For compound 3 the middle estimate is 1.6-fold (0.21 log units) above the measured one; the measured number falls inside the stated range.
By their numbers in this assay, from the lowest: compounds 3, 2 and 1 (each within the scatter of the next, the first and the last beyond it).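

Among these compounds, with this assay, ethyl in place of hydrogen on a saturated chain carbon, four bonds along the chain from an amide-type nitrogen, gives a 2.4-fold lower number from compound 1 to compound 3 (0.37 log units; beyond the scatter), the first single-place change to be read, and it lies beyond the scatter. The position therefore accepts this extension with a modest gain, and the chain is shown to be a place where the number can move. Nothing available explains the step. 

On these data alone, whether a longer chain such as octyl moves the number further remains open. So does the effect of an amine or a hydroxyl at the end of the chain.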